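This account rests on a few compounds, and the source may have more. Where it says the series, first, only, none or still open, it means among the compounds named here.

Compound 1 `CC1(Cc2ccccc2)CC(S(=O)(=O)c2ccccc2)=C(c2ccc(/C(N)=N/O)cc2)O1`: 94600 nM
Compound 2 `CC1(Cc2ccccc2)CC(S(=O)(=O)c2ccc(/C(N)=N/O)cc2)=C(c2ccc(Nc3ccc(/C(N)=N/O)cc3)cc2)O1`: 9800 nM
Compound 3 `N/C(=N\O)c1ccc(C2=C(S(=O)(=O)c3ccc(Nc4cccc(/C(N)=N/O)c4)cc3)CC(c3ccccc3)(c3ccccc3)O2)cc1`: > 50000 nM

In an ADME assay on THP-1 cells (Homo sapiens) for cytotoxicity, read by flow cytometry, with a stated time of 72 h (a higher number here means a weaker inhibitor, a lower number a stronger inhibitor), compound 2 gives the lowest of the two numbers; the nearest, compound 1, gives a higher number, a gap beyond the scatter. Compound 3 sits at the limit of > 50000 nM in this assay, at which 1 of the 3 values shown sits, so for it only a limit is known. Compound 4 `CC1(Cc2ccccc2)CC(S(=O)(=O)c2ccc(/C(N)=N/O)cc2)=C(c2ccc(Nc3cccc(/C(N)=N/O)c3)cc2)O1` is not yet measured; it differs from compound 2 by a group of 10 heavy atoms (7 carbon, 2 nitrogen, 1 oxygen; one six-membered aromatic ring of carbon only) in place of a group of 10 heavy atoms (7 carbon, 2 nitrogen, 1 oxygen; one six-membered aromatic ring of carbon only), on a nitrogen on an aromatic ring. For the measured compounds named here, no pair of measured compounds isolates this change, so the expectation rests on compound 2 alone. A move of this kind is expected to shift the number upward by a modest step, not far beyond the scatter, so the step from compound 2 to compound 4 is estimated as a 1.6-fold higher number from compound 2 to compound 4 (0.21 log units; within the scatter). Compound 4 is expected near 16000 nM, in a range from 5000 nM to 50000 nM.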

Compound 4, half-maximal inhibitory concentration: 44000 nM
For compound 4 the middle estimate is 2.8-fold (0.44 log units) below the measured one; the measured number falls inside the stated range.
By their numbers in this assay, from the lowest: compound 2; then compound 4; then compound 1.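

On a nitrogen on an aromatic ring, replacing one group of 10 heavy atoms with another that has the same atoms joined differently changes the result in this assay: a 4.5-fold higher number from compound 2 to compound 4 (0.65 log units; beyond the scatter). For the compounds shown here, this is the first measured pair that differs in one place, and it shows that this position responds even when the counted atoms, hydrogen-bond donors and acceptors stay the same.

From the compounds shown here alone, compound 3 gives only a limit, so it cannot show whether the change behaves alike on another core: the limit of > 50000 nM in this assay, at which 1 of the 4 values shown sits. How a carboxylic acid or an amine at this position would affect this assay remains open.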